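The source may hold more compounds than are shown below. What is called first, only, known or untested is meant among the compounds shown, and "the series" means these compounds.

Measured compounds:
- compound 1, `Cc1ccc(Sc2cnc(Nc3ccccn3)s2)cc1C(N)=O`, 790 nM
- compound 2, `Cc1ccc(Sc2cnc(Nc3ccccn3)s2)cc1C(=O)NC(C)C`, 2000 nM

Among the measured compounds shown here, compound 1 gives the lower of the two numbers in an assay on isolated protein for inhibition of high affinity nerve growth factor receptor (Homo sapiens) (a higher number here means a weaker inhibitor, a lower number a stronger inhibitor), with compound 2 as its only neighbour; the single step recorded, a 2.5-fold higher number from compound 1 to compound 2 (0.40 log units; beyond the scatter), is a modest weakening. Compound 3, `Cc1ccc(Sc2cnc(Nc3ccccn3)s2)cc1C(=O)NCCC#N`, has not yet been measured in this assay. It differs from compound 1 by 2-cyanoethyl in place of hydrogen on an amide-type nitrogen. For the measured compounds named here, the only measured step that bears on this change is the one from compound 1 to compound 2, where a larger group entered at the same amide-type nitrogen and the number rose beyond the scatter. The 2-cyanoethyl group is not an isopropyl group, so this step is a guide only to direction rather than to exact size, and a chain with a nitrile and one hydrogen-bond acceptor might behave differently from a branched alkyl. On the evidence of compound 2, a modest weakening relative to compound 1 is the most reasonable expectation, and compound 3 is therefore estimated to show a 1.9-fold higher number from compound 1 to compound 3 (0.28 log units; within the scatter). The estimated value for compound 3 is 1500 nM, within the range 600 nM to 4000 nM.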

Compound 3, half-maximal inhibitory concentration: 65 nM
The estimate for compound 3 lay 23-fold (1.36 log units) above the measured number; the whole stated range lies above it.
By their numbers in this assay, from the lowest: compound 3; then compound 1; then compound 2.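

In this assay, placing a group on the amide-type nitrogen does not always go with a higher number: 2-cyanoethyl in place of hydrogen gives a 12-fold lower number from compound 1 to compound 3 (1.08 log units; beyond the scatter) and so runs opposite to the step seen with isopropyl at the same nitrogen. Exchanging isopropyl for 2-cyanoethyl at this nitrogen gives a 31-fold lower number from compound 2 to compound 3 (1.49 log units; beyond the scatter) and is the largest step among the three compounds, so the outcome here depends strongly on which group enters and not merely on whether the amide hydrogen is replaced. No evidence is available that bears on what lies behind this difference between the two groups.

The compounds shown leave open whether the gain belongs to the nitrile or to the unbranched chain that carries it, a question that a plain n-propyl group or a 2-methoxyethyl group at the same nitrogen would address. They also leave open how the number responds to the length of the chain, as with 3-cyanopropyl, or to a different end group on it, such as a primary amine or a carboxylic acid.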